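Methyl in Place of Chloro on a Second Core

A few compounds are considered here, and "the series" means these few. Any claim that something is new, unique, unknown or untested is made for them only; others in the source may bear on it.

Compound 1 `O=C1Nc2ccc(Br)cc2/C1=N/NC(=S)Nc1ccc(Cl)cc1` carries a chloro group on its outer ring; in a functional assay on MOLT-4 cells (Homo sapiens), with a stated time of 72 h (on this read-out higher numbers stand for weaker inhibition and lower numbers for stronger inhibition), compound 1 gives 29000 nM. Compound 2 `Cc1ccc(NC(=S)N/N=C2\C(=O)Nc3ccc(Br)cc32)cc1` differs from it by methyl in place of chloro on an aromatic carbon, and in this assay compound 2 gives 4900 nM, which is a 5.9-fold lower number from compound 1 to compound 2 (0.77 log units; beyond the scatter). Compound 3 `O=C1Nc2cc(Cl)c(F)cc2/C1=N/NC(=S)Nc1ccc(Cl)cc1` has a different core; the difference between the two cores is not broken down here. In this assay compound 3 gives 43000 nM, close to compound 1. Compound 4 `Cc1ccc(NC(=S)N/N=C2\C(=O)Nc3cc(Cl)c(F)cc32)cc1`, not yet measured, differs from compound 3 by methyl in place of chloro on an aromatic carbon, the same change seen once before. Within the data shown here, because the earlier change gave a 5.9-fold lower number from compound 1 to compound 2 (0.77 log units; beyond the scatter), for compound 4 the expected step is a 5.4-fold lower number from compound 3 to compound 4 (0.73 log units; beyond the scatter), though the cores differ and only one earlier example exists. Compound 4 is estimated at 8000 nM, with a range from 3000 nM to 25000 nM.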

Compound 4, half-maximal inhibitory concentration: 112000 nM
Beside the measured number, compound 4's estimate is 14-fold (1.15 log units) below it, and the stated range ends below it.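

In this assay, the swap of chloro for methyl does not carry over from one core to the other: the same change on two cores in this assay, a 5.9-fold lower number (0.77 log units; beyond the scatter) from compound 1 to compound 2 and a 2.6-fold higher number (0.42 log units; beyond the scatter) from compound 3 to compound 4, 15-fold (1.19 log units) apart, beyond the scatter of two such steps. On the second core the swap gives a 2.6-fold higher number from compound 3 to compound 4 (0.42 log units; beyond the scatter), so the number moves in the opposite direction from the first core. This shows that the result of the swap in this series depends on the core it sits on, but two pairs do not show which difference between the cores matters or what a third core would do.

The compounds shown leave open how an amine or a methoxy group in place of the chloro would behave on either core. They also leave open whether the bromo on one core or the chloro and fluoro on the other goes with the reversal.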